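The source may hold more compounds than are shown below. What is called first, only, known or untested is meant among the compounds shown, and "the series" means these compounds.

Measured in an ADME assay on Caco-2 cells (Homo sapiens) for permeability, read by LC-MS, in the apical to basolateral direction, with a stated time of 60 min, at pH 6.5; a lower number here means that the compound crosses the layer more slowly, a higher number that the compound crosses the layer faster:

Compound 1 `Cc1cccc([C@@H](O)C(=O)N2N=CC[C@H]2C(=O)NCc2cc(Cl)ccc2-n2cnnn2)c1` gives 9.7 10^-6 cm/s.
Compound 2 `O=C(NCc1cc(Cl)ccc1-n1cnnn1)[C@@H]1[C@@H]2C[C@@H]2CN1C(=O)[C@H](O)c1ccccc1` gives 2.2 10^-6 cm/s.
Compound 3 `O=C(NCc1cc(Cl)ccc1-n1cnnn1)[C@@H]1[C@@H]2C[C@@H]2CN1C(=O)[C@H](O)Cc1ccccn1` gives 0.62 10^-6 cm/s.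

Compound 3 stands lowest of the three in this assay; compound 2 is nearest to it and compound 1 furthest. Among the compounds with values here, the only single-point step on record is a 3.5-fold lower number from compound 2 to compound 3 (0.55 log units; beyond the scatter), which is the one that bears on the next compound.

Compound 4 `O=C(NCc1cc(Cl)ccc1-n1cnnn1)[C@@H]1[C@@H]2C[C@@H]2CN1C(=O)[C@H](O)c1ccccc1F` differs from compound 3 as follows: 2-fluorophenyl in place of (pyridin-2-yl)methyl on a saturated chain carbon bound to a carbonyl carbon and an oxygen on a saturated carbon. The group that enters, 2-fluorophenyl, is close to the phenyl that compound 2 carries at the same place, so compound 4 is read as a near return to compound 2 with a fluorine added. The step of a 3.5-fold lower number from compound 2 to compound 3 (0.55 log units; beyond the scatter) therefore gives the expected size and, reversed, the expected direction: an upward step beyond the scatter in this assay, with the fluorine as an unknown of modest weight. Within the data shown here, no measured compound shows what a fluorine on that ring does, so the range is kept wide.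

Compound 4 is expected to give 2.5 10^-6 cm/s in this assay, within 1 10^-6 cm/s to 6 10^-6 cm/s, that is an expected step of a 4.0-fold higher number from compound 3 to compound 4 (0.61 log units; beyond the scatter).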

Compound 4, apparent permeability: 2.3 10^-6 cm/s
The estimate for compound 4 lay 1.1-fold (0.04 log units) above the measured number; measured number inside the range.
By their numbers in this assay, from the lowest: compound 3; then compounds 2 and 4 (each within the scatter of the next); then compound 1.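

In this assay the exchange of (pyridin-2-yl)methyl for 2-fluorophenyl gives a 3.7-fold higher number from compound 3 to compound 4 (0.57 log units; beyond the scatter) and so shows that the low number of compound 3 does not persist once that group leaves this place. Fluoro in place of hydrogen on the aromatic ring gives a 1.0-fold higher number from compound 2 to compound 4 (0.02 log units; within the scatter) and is the first reading of a substituent on this ring, with compounds 2 and 4 standing level within the scatter. No measured evidence bears on the reason for either step.

Compound 3 differs from compounds 2 and 4 in both its ring and its added chain carbon, so the shown compounds do not separate these two features. A benzyl or a pyridin-2-yl group at this place would address that, while a methoxy or chloro group on the phenyl ring would test whether the fluoro result extends to other substituents.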